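The compounds below may be only part of what the source reports. "The series", "measured", "known", "first", "only" and "open" are said of these compounds alone.

Measured so far in a functional assay on MKN-45 cells (Homo sapiens) for cytotoxicity, read by MTT assay, with a stated time of 48 h; a higher number here means a weaker inhibitor, a lower number a stronger inhibitor:

Compound 1, `CCc1nnc(SCC(=O)c2ccc(C)cc2)n1N1C(=O)c2ccccc2C1=O`: compound 1 gives > 200000 nM, a limit of the assay.
Compound 2, `CCCc1nnc(SCC(=O)c2ccc(C)cc2)n1N1C(=O)c2ccccc2C1=O`: compound 2 gives > 200000 nM, a limit of the assay.
Compound 3, `CCCc1nnc(SC)n1N1C(=O)c2ccccc2C1=O`: compound 3 gives > 200000 nM, a limit of the assay.

Compound 2 thus stands only at the limit of > 200000 nM in this assay, at which 3 of the 3 values shown sit; no number is known for it. The two measured steps around it, a step that the two limits leave unreadable from compound 1 to compound 2 and a step that the two limits leave unreadable from compound 2 to compound 3, give no readable size, so nothing within the series shows how far a change on this scaffold can move the read-out.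

The next compound, compound 4, is `COc1cc(-c2nnc(SCC(=O)c3ccc(C)cc3)n2N2C(=O)c3ccccc3C2=O)cc(OC)c1OC`. It differs from compound 2 by 3,4,5-trimethoxyphenyl in place of propyl on an aromatic carbon. Neither measured step touches the aromatic carbon of the five-membered ring with three nitrogen; both alter the chain on the sulfur or the saturated chain on the other side of the ring, and both stay unreadable. Within the data shown here, there is therefore no measured precedent for the step from propyl to 3,4,5-trimethoxyphenyl, and the expectation rests on the series sitting wholly at the limit.

The step from compound 2 to compound 4 is expected as an at least 1.6-fold lower number from compound 2 to compound 4 (0.22 log units; that floor lies within the scatter). Compound 4 is estimated at 120000 nM, between 15000 nM and 400000 nM, with a fair chance that this assay again returns only a limit.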

Compound 4, half-maximal inhibitory concentration: 9620 nM
Compound 4: middle estimate off by 12-fold (1.10 log units), on the high side, and the stated range ends above it.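

In this assay, among these compounds, the aromatic carbon of the five-membered aromatic ring with 3 nitrogen is the first place on this scaffold where a change gives a readable effect: 3,4,5-trimethoxyphenyl in place of propyl gives an at least 20-fold lower number from compound 2 to compound 4 (1.31 log units; beyond the scatter). With ethyl as the group that leaves, the result is an at least 20-fold lower number from compound 1 to compound 4 (1.31 log units; beyond the scatter), so the two saturated chains serve as equivalent starting points only in that both sit at a limit, and each step is bounded on one side only. The steps among compound 1, compound 2 and compound 3 cannot be read, and compound 4 is the only compound shown with a number, so its result gives the series its first measured value, while the rest stays at the limit: the limit of > 200000 nM in this assay, at which 3 of the 4 values shown sit.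

On these data alone, it remains open whether an unsubstituted phenyl or a cyclohexyl at this aromatic carbon would also leave the limit, so the step cannot yet be divided between the aromatic ring and its methoxy groups. Also open, as far as these compounds go, is whether 3,4,5-trimethoxyphenyl keeps this effect when the (4-methylphenyl)carbonyl chain on the sulfur gives way to a plain methyl or to a carboxylic acid.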